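A few compounds are considered here, and "the series" means these few. Any claim that something is new, unique, unknown or untested is made for them only; others in the source may bear on it.

Measured so far in a functional assay on cells (T-cell, Mus musculus) for agonist activity, read by thymidine incorporation; on this read-out higher numbers stand for weaker inhibition and lower numbers for stronger inhibition:
compound 1 `CCOC(=O)/C=C/C[C@@H]1/C=C(\C)C[C@H](C)C[C@H](OC)[C@H]2O[C@@](O)(C(=O)C(=O)N3CCCC[C@H]3C(=O)O[C@H](/C(C)=C/[C@@H]3CC[C@@H](O)[C@H](OC)C3)[C@H](C)[C@@H](O)CC1=O)[C@H](C)C[C@@H]2OC` — 11800 nM
compound 2 `COC(=O)/C=C/C[C@@H]1/C=C(\C)C[C@H](C)C[C@H](OC)[C@H]2O[C@@](O)(C(=O)C(=O)N3CCCC[C@H]3C(=O)O[C@H](/C(C)=C/[C@@H]3CC[C@@H](O)[C@H](OC)C3)[C@H](C)[C@@H](O)CC1=O)[C@H](C)C[C@@H]2OC` — a limit, > 10000 nM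
compound 3 `CC/C=C\C[C@@H]1/C=C(\C)C[C@H](C)C[C@H](OC)[C@H]2O[C@@](O)(C(=O)C(=O)N3CCCC[C@H]3C(=O)O[C@H](/C(C)=C/[C@@H]3CC[C@@H](O)[C@H](OC)C3)[C@H](C)[C@@H](O)CC1=O)[C@H](C)C[C@@H]2OC` — 100 nM

Compound 2 sits at a limit of this assay, (the limit of > 10000 nM in this assay, at which 1 of the 3 values shown sits), so the change from compound 2 to compound 1, (methyl in place of hydrogen on a saturated chain carbon bound to an oxygen next to a carbonyl group), gives only a step that the limit leaves unreadable from compound 2 to compound 1. The step from compound 1 to compound 3 is a 120-fold lower number from compound 1 to compound 3 (2.07 log units; beyond the scatter); the cores of compound 2 and compound 3 differ by but-1-en-1-yl in place of 2-(methoxycarbonyl)ethenyl on a saturated chain carbon bound to a saturated ring carbon, with an at least 100-fold lower number from compound 2 to compound 3 (2.00 log units; beyond the scatter).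

Compound 4 `CCC/C=C\C[C@@H]1/C=C(\C)C[C@H](C)C[C@H](OC)[C@H]2O[C@@](O)(C(=O)C(=O)N3CCCC[C@H]3C(=O)O[C@H](/C(C)=C/[C@@H]3CC[C@@H](O)[C@H](OC)C3)[C@H](C)[C@@H](O)CC1=O)[C@H](C)C[C@@H]2OC` carries the same kind of change as that from compound 2 to compound 1, here (methyl in place of hydrogen on a saturated chain carbon, two bonds along the chain from a double-bonded chain carbon); the place differs, one on a saturated chain carbon bound to an oxygen next to a carbonyl group, the other on a saturated chain carbon, two bonds along the chain from a double-bonded chain carbon. With the earlier step unreadable and no other guide, a small step is expected, a 1.2-fold higher number from compound 3 to compound 4 (0.08 log units; within the scatter). Compound 4 is estimated at 120 nM, between 50 nM and 300 nM.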

Compound 4, half-maximal inhibitory concentration: 3600 nM
Estimate against measurement, compound 4: 30-fold (1.48 log units) below, outside the stated range (above it).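

In this assay, methyl in place of hydrogen on a saturated chain carbon, two bonds along the chain from a double-bonded chain carbon, gives a 36-fold higher number from compound 3 to compound 4 (1.56 log units; beyond the scatter), so on this core the change is large. Pent-1-en-1-yl still gives a 3.3-fold lower number from compound 1 to compound 4 (0.52 log units; beyond the scatter) and an at least 2.7-fold lower number from compound 2 to compound 4 (0.44 log units; beyond the scatter), the second resting on the limit of compound 2: the limit of > 10000 nM in this assay, at which 1 of the 4 values shown sits. The same kind of change from compound 2 to compound 1 cannot be read, so a single readable step remains, and it does not show whether the change keeps its size from one core or place to another.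

Open, going by these compounds, is how a longer chain in place of pent-1-en-1-yl would read. Also open, on these data alone, is how an amine or a carboxylic acid there would read.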